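Trading a Sulfonyl Group for Butoxycarbonyl

A few compounds are considered here, and "the series" means these few. Any claim that something is new, unique, unknown or untested is made for them only; others in the source may bear on it.

Of the compounds shown here, two have been measured so far in a functional assay (plasma) for inhibition, with Homo sapiens as the target; a lower number here means a stronger inhibitor, a higher number a weaker inhibitor. Compound 1 `Cc1ccc(S(=O)(=O)N[C@@H](CNC(=O)c2ccc3nc(-c4ccc(C(=N)N)cc4)oc3c2)C(=O)O)cc1` gives 10 nM, while compound 2 `NCc1ccc(Cn2cnc3cc(C(=O)NCCC(=O)O)ccc32)cc1` gives 83000 nM. Compound 1 therefore has the lower of the two numbers, and the gap lies well beyond the usual scatter of repeated measurements.

The next molecule of interest, compound 3 `CCCCOC(=O)N[C@@H](CNC(=O)c1ccc2nc(-c3ccc(C(=N)N)cc3)oc2c1)C(=O)O`, still awaits its measurement. It has butoxycarbonyl in place of (4-methylphenyl)sulfonyl on an amine nitrogen. The change therefore removes one six-membered aromatic ring of carbon only, and the rest of compound 1 stays as it is.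

Going by the values given here, no measured pair shows what this kind of swap does, so any forecast here carries real uncertainty. The wide gap between the two measured values does not settle the question either. Among the compounds with values here, a modest loss seems the most reasonable expectation, since only one group changes while the rest of the structure is kept. The expected step is a 2.5-fold higher number from compound 1 to compound 3 (0.40 log units; beyond the scatter), a small move toward weaker inhibition. For compound 3 the estimate is 25 nM, with an expected range of 7 nM to 90 nM.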

Compound 3, half-maximal inhibitory concentration: 20 nM
Compound 3: the middle estimate sits 1.3-fold (0.10 log units) above what was measured; the measured number falls inside the stated range.
By their numbers in this assay, from the lowest: compounds 1 and 3 (each within the scatter of the next); then compound 2.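

In this assay the swap of (4-methylphenyl)sulfonyl for butoxycarbonyl on the amine nitrogen gives a 2.0-fold higher number from compound 1 to compound 3 (0.30 log units; within the scatter) and so compound 1 and compound 3 read as equal inhibitors. Going by these compounds alone, this is the first look at this position, and it shows that the group on this nitrogen need not carry a six-membered aromatic ring of carbon only, nor a sulfonyl: an open butoxycarbonyl chain of 7 heavy atoms serves as well here as the ringed group of 10 heavy atoms. No supporting measurement explains why the two groups read alike, so the result stands as an observation only.

The pair leaves open how much of the group this nitrogen needs, since a short acetyl group, a longer chain such as octyloxycarbonyl or a bare amine with nothing added could each behave quite differently. A single swap also cannot show whether the same tolerance would hold with a different part of the core changed, for example with an ester in place of the carboxylic acid.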